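The source may hold more compounds than are shown below. What is called first, only, known or untested is meant among the compounds shown, and "the series" means these compounds.

Measured so far:
- compound 1, `CCCNC(=O)Cn1nc(N)c2c(C(F)(F)F)cc(-c3ccccc3)nc21`: 16500 nM
- compound 2, `Nc1nn(CC(=O)NCc2ccco2)c2nc(-c3ccccc3)cc(C(F)(F)F)c12`: 7700 nM

Of the compounds shown here, two have been tested in a functional assay on A549 cells (Homo sapiens) for cytotoxicity, read by MTT assay, with a stated time of 24 h; on this read-out higher numbers stand for weaker inhibition and lower numbers for stronger inhibition. Compound 1 gives 16500 nM, and compound 2 gives 7700 nM. Going by the values given here, the only measured step, a 2.1-fold lower number from compound 1 to compound 2 (0.33 log units; beyond the scatter), concerns the group carried on the saturated chain carbon bound to the amide-type nitrogen. On the numbers at hand compound 2 holds the lowest value of the two; its nearest neighbour is compound 1, and the gap between them is the step just given, which lies beyond the scatter.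

The next compound, compound 3, is `Nc1nn(CC(=O)N2CCCC2)c2nc(-c3ccccc3)cc(C(F)(F)F)c12`. It differs from compound 2 in one place: pyrrolidin-1-yl in place of ((furan-2-yl)methyl)amino on a carbonyl carbon. Among the compounds with values here, no measured step tests this kind of change: the step from compound 1 to compound 2 swapped one group for another while keeping the amide hydrogen, whereas here the amide hydrogen disappears along with the furan ring. Within the data shown here, the only guidance is that both measured values lie close together, so a number near compound 2 is the default expectation, with a wide margin. The expected step is a 1.3-fold higher number from compound 2 to compound 3 (0.11 log units; within the scatter). Compound 3 is estimated at 10000 nM, within a range of 4000 nM to 30000 nM.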

Compound 3, half-maximal inhibitory concentration: 18700 nM
The estimate for compound 3 lay 1.9-fold (0.27 log units) below the measured number; low and high end bracket the measured number.
By their numbers in this assay, from the lowest: compound 2; then compounds 1 and 3 (each within the scatter of the next).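

In this assay, putting pyrrolidin-1-yl in place of ((furan-2-yl)methyl)amino on the carbonyl carbon gives a 2.4-fold higher number from compound 2 to compound 3 (0.39 log units; beyond the scatter), so the lower number does not survive a change that removes the furan ring and the amide hydrogen together. Putting pyrrolidin-1-yl in place of propylamino on the same carbonyl carbon gives a 1.1-fold higher number from compound 1 to compound 3 (0.05 log units; within the scatter), which shows that a ring on this carbon does not by itself set the number apart from a simple chain, and that among these three groups only ((furan-2-yl)methyl)amino stands out. No measurement in hand explains this difference between the groups.

Still open is whether the furan ring or the amide hydrogen matters more, since both leave in the same change and the compounds shown cannot separate them. A benzylamino group would test a different aromatic ring with the amide hydrogen kept, while a ((furan-2-yl)methyl)(methyl)amino group would keep the furan ring and lose that hydrogen.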